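Halogen to methoxy swap on the fused ring

The source may report more compounds than this note shows. Statements on the series, on what has been measured and on what is new or still open speak of the compounds shown alone.

Measured compounds in a functional assay on HEK293 cells for agonist activity at Free fatty acid receptor 1 (Homo sapiens), read by fluorescence and calcium flux, with a stated time of 10 min; a lower number here means a smaller maximal response, a higher number a larger maximal response:
compound 1 `CC#C[C@@H](CC(=O)O)c1ccc(OC[C@H]2COc3ccc(Cl)cc3O2)cc1`: 86%
compound 2 `CC#C[C@@H](CC(=O)O)c1ccc(OC[C@H]2COc3ccccc3O2)cc1`: 70%
compound 3 `CC#C[C@@H](CC(=O)O)c1ccc(OC[C@H]2COc3ccc(Br)cc3O2)cc1`: 69%

Compound 3 gives the lowest number of the three, though its gap to compound 2 lies within the scatter; only compound 1 stands clearly higher, as a number 17 percentage points lower from compound 1 to compound 3 (beyond the scatter) shows. Compound 4 `CC#C[C@@H](CC(=O)O)c1ccc(OC[C@H]2COc3ccc(OC)cc3O2)cc1` differs from compound 3 in one place: methoxy in place of bromo on an aromatic carbon. Among the measured compounds shown here, no measured step exchanges a halogen for methoxy, so the expectation rests on indirect comparisons. The nearest are a number 1 percentage points lower from compound 2 to compound 3 (within the scatter), within the scatter, and a number 16 percentage points lower from compound 1 to compound 2 (beyond the scatter), a modest step. Since bromo entering for hydrogen changed nothing beyond the scatter, the step of a number 3 percentage points higher from compound 3 to compound 4 (within the scatter) is expected to remain within the scatter. For compound 4 the estimate in this assay is 72%, ranging from 60% to 85%.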

Compound 4, largest response reached (Emax), in percent of the reference or control that the assay uses: 91%
The estimate for compound 4 lay 19 percentage points below the measured number, and the stated range ends below it.
By their numbers in this assay, from the lowest: compounds 3 and 2 (each within the scatter of the next); then compounds 1 and 4 (each within the scatter of the next).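

Working from this assay, the position tolerates more than a halogen or hydrogen: methoxy gives a number 22 percentage points higher from compound 3 to compound 4 (beyond the scatter) and a number 21 percentage points higher from compound 2 to compound 4 (beyond the scatter), whereas bromo for hydrogen moved nothing beyond the scatter. Methoxy and chloro cannot be told apart, with a number 5 percentage points higher from compound 1 to compound 4 (within the scatter), so two quite different groups share the upper level while bromo sits with hydrogen. Nothing available accounts for this grouping.

Open, going by these compounds, is whether ethoxy, an amine or a nitrile at this place would join the upper or the lower level. Also open, on these data alone, is whether the methoxy result carries over to the other positions of the fused ring.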